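Compound 3 to compound 4: phenoxy for 3-hydroxyphenyl

The compounds below may be only part of what the source reports. "The series", "measured", "known", "first", "only" and "open" are said of these compounds alone.

In a physicochemical assay for solubility, read by HPLC, in phosphate buffer, with a stated time of 24 h, at pH 7.4 (a lower number here means a less soluble compound, a higher number a more soluble compound), compound 3 `COc1ccc(Cn2nnc(O)c2C(=O)Nc2cccc(-c3cccc(O)c3)c2)cc1` gives 40300 nM. Compound 1 `COc1ccc(Cn2nnc(O)c2C(=O)Nc2cccc(C(F)(F)F)c2)cc1` gives 21200 nM, which cannot be told apart from the value of compound 3. Compound 2 `COc1ccc(Cn2nnc(O)c2C(=O)Nc2cc(C(F)(F)F)cc(C(F)(F)F)c2)cc1` gives 6910 nM, lower than the value of compound 3 by more than the scatter.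

Compound 4 `COc1ccc(Cn2nnc(O)c2C(=O)Nc2cccc(Oc3ccccc3)c2)cc1` differs from compound 3 at one place, on an aromatic carbon meta to a large group: phenoxy in place of 3-hydroxyphenyl on an aromatic carbon. Phenoxy stands in place of 3-hydroxyphenyl, and the two compounds have the same atoms, joined differently.

Among the compounds with values here, two measured steps bear on this change, neither directly. At the same place, 3-hydroxyphenyl in place of trifluoromethyl gave a 1.9-fold higher number from compound 1 to compound 3 (0.28 log units; within the scatter). Trifluoromethyl in place of hydrogen on an aromatic carbon gave a 3.1-fold lower number from compound 1 to compound 2 (0.49 log units; beyond the scatter), a modest step. Within the data shown here, no measured pair tests phenoxy itself, so the size of the step rests on these two alone. Values so far run from compound 2 at 6910 nM to compound 3 at 40300 nM, which makes a move down likelier than a move up, though only weakly so. The expected step, modest at most, is a 2.5-fold lower number from compound 3 to compound 4 (0.40 log units; beyond the scatter). For compound 4 the estimated value is 16000 nM, with an expected range of 6000 nM to 42000 nM.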

Compound 4, solubility: < 1000 nM
Compound 4: only a limit was reported (the forecaster's own chance of this, stated with the estimate: 3%); middle value at least 16-fold (1.20 log units) away from the limit.
By their numbers in this assay, from the lowest: compound 2; then compounds 1 and 3 (each within the scatter of the next). At a limit, below all of these: compound 4.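

In this assay compound 4 stands at a limit of the assay and not at a number: the limit of < 1000 nM in this assay, at which 1 of the 4 values shown sits.

This position, where trifluoromethyl and 3-hydroxyphenyl could not be told apart, turns out to allow a far larger step, and a rearrangement of the same atoms is enough to produce it: an at least 40-fold lower number from compound 3 to compound 4 (1.60 log units; beyond the scatter). The comparison with trifluoromethyl at the same place gives an at least 21-fold lower number from compound 1 to compound 4 (1.32 log units; beyond the scatter), so phenoxy separates from both other groups here, and both steps are bounds whose full size is not known.

The change alters two things at once, the link to the ring and the count of hydrogen-bond donors, from 1 in 3-hydroxyphenyl to 0 in phenoxy, and the compounds shown cannot separate them; an unsubstituted phenyl or a 3-hydroxyphenoxy group at this place would divide the two. Also open, going by these compounds, is whether an amine or a carboxylic acid on the phenoxy ring would bring the number back above the limit.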